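From Hydroxy to Bromo: Estimating Compound 4

The source may hold more compounds than are shown below. What is called first, only, known or untested is meant among the compounds shown, and "the series" means these compounds.

In a functional assay on OVCAR-3 cells (Homo sapiens) for inhibition, read by MTT assay, with a stated time of 24 h (on this read-out higher numbers stand for weaker inhibition and lower numbers for stronger inhibition), compound 3 `CC1(C)[C@H]2CC[C@]1(C)N(Cc1cn(-c3cccc(O)c3)nn1)C(=O)C2` gives 370 nM. Compound 1 `CC1(C)[C@H]2CC[C@]1(C)N(Cc1cn(-c3ccccc3F)nn1)C(=O)C2` gives 300 nM, and the comparison shows a 1.2-fold higher number from compound 1 to compound 3 (0.09 log units; within the scatter), so these two cannot be told apart. Compound 2 `CC1(C)[C@H]2CC[C@]1(C)N(Cc1cn(-c3ccccc3)nn1)C(=O)C2`, which has no substituent on the outer aromatic ring, gives 50 nM, so compound 3 stands well clear of it.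

Compound 4 `CC1(C)[C@H]2CC[C@]1(C)N(Cc1cn(-c3cccc(Br)c3)nn1)C(=O)C2` differs from compound 3 by bromo in place of hydroxy on an aromatic carbon. Among the measured compounds shown here, no measured step involves bromo, so the evidence is indirect. Adding hydroxy gave a 7.4-fold higher number from compound 2 to compound 3 (0.87 log units; beyond the scatter), and removing fluoro gave a 6.0-fold lower number from compound 1 to compound 2 (0.78 log units; beyond the scatter). In these three compounds, then, both substituents go with a higher number than hydrogen, and none goes against this. Bromo may behave likewise, which would keep compound 4 closer to compound 3 than to compound 2. The expected change is therefore small, a 1.9-fold lower number from compound 3 to compound 4 (0.27 log units; within the scatter). The estimate for compound 4 is 200 nM, with an expected range from 60 nM to 600 nM.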

Compound 4, half-maximal inhibitory concentration: 30 nM
Estimate against measurement, compound 4: 6.7-fold (0.82 log units) above; measured number outside the range, below it.
By their numbers in this assay, from the lowest: compounds 4 and 2 (each within the scatter of the next); then compounds 1 and 3 (each within the scatter of the next).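

In this assay, the group at this place on the aromatic ring matters a great deal: a 12-fold lower number from compound 3 to compound 4 (1.09 log units; beyond the scatter) comes from exchanging hydroxy for bromo, one heavy atom for another. The earlier compounds shown here suggested that a substituent goes with a higher number than hydrogen, but compound 4 goes against this, since a 1.7-fold lower number from compound 2 to compound 4 (0.22 log units; within the scatter) lies within the scatter, so bromo here cannot be told apart from hydrogen. A substituent on this ring therefore does not by itself cost inhibition, and a 10-fold lower number from compound 1 to compound 4 (1.00 log units; beyond the scatter) shows that 3-bromophenyl also stands clearly apart from 2-fluorophenyl.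

As far as these compounds go, whether chloro, methyl or an amine at this same place would track bromo or hydroxy remains open. Nothing given here accounts for the gap between bromo and hydroxy.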